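The source may report more compounds than this note shows. Statements on the series, on what has been measured and on what is new or still open speak of the compounds shown alone.

Measured in an ADME assay on HepG2 cells (Homo sapiens) for inhibition, read by fluorescence and resazurin assay, with a stated time of 72 h; on this read-out higher numbers stand for weaker inhibition and lower numbers for stronger inhibition:
- compound 1 `Cc1cccc(Nc2ncc(Cl)c(Nc3ccc4nc[nH]c4c3)n2)c1` gives 7400 nM 
- compound 2 `Cc1cccc(Nc2nccc(Nc3ccc4cn[nH]c4c3)n2)c1` gives 15000 nM 
- compound 3 `Brc1ccc(Nc2nccc(Nc3ccc4cn[nH]c4c3)n2)cc1` gives 20000 nM 

Not yet measured: compound 4 `CN1CCN(c2cccc(Nc3nccc(Nc4ccc5cn[nH]c5c4)n3)c2)CC1`

Compound 2 stands level with compound 3 within the scatter, and compound 1 shows a lower number than either. The open question is the change from compound 2 to compound 4: 4-methylpiperazin-1-yl in place of methyl on an aromatic carbon. This places 4-methylpiperazin-1-yl in place of methyl on an aromatic carbon.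

Within the data shown here, only one measured step bears on this change: a 1.3-fold higher number from compound 2 to compound 3 (0.12 log units; within the scatter). That step puts 4-bromophenyl in place of 3-methylphenyl on a nitrogen on an aromatic ring. It stays within the scatter, but it brings in no group like the entering one, so it is only a loose guide. Compound 1 differs from compound 2 in more than one place and gives no clean comparison.

Among the measured compounds shown here, no measured compound carries a group of this size, so the direction in this assay remains tentative. A modest move to a lower number is expected, close to the edge of the scatter. The expected change is a 2.1-fold lower number from compound 2 to compound 4 (0.33 log units; beyond the scatter) and the wide range reflects how little the data constrain it. For compound 4 the estimate is 7000 nM, with an expected range from 2000 nM to 22000 nM.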

Compound 4, half-maximal inhibitory concentration: 6700 nM
Compound 4: middle estimate off by 1.0-fold (0.02 log units), on the high side; measured number inside the range.
By their numbers in this assay, from the lowest: compounds 4 and 1 (each within the scatter of the next); then compounds 2 and 3 (each within the scatter of the next).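

In this assay, among these compounds, this is the first change made at this aromatic carbon alone, as the earlier step (a 1.3-fold higher number from compound 2 to compound 3 (0.12 log units; within the scatter)) replaced the whole substituted phenyl group and stayed within the scatter. Replacing methyl with 4-methylpiperazin-1-yl gives a modest step beyond the scatter (a 2.2-fold lower number from compound 2 to compound 4 (0.35 log units; beyond the scatter)), so this place accepts a group of seven heavy atoms, with a six-membered non-aromatic ring holding two hetero atoms, and the number moves lower rather than higher. Nothing available accounts for the direction of this step, and a single pair cannot separate the contribution of the ring from that of its nitrogens.

Going by these compounds, whether the step follows from the ring itself, its two nitrogens or the terminal methyl stays open, and a morpholine, a piperidine or a simple dimethylamino group at the same carbon would begin to separate these parts. Also open, on these data alone, is whether the same replacement would give a step of similar size and direction on the core of compound 1, or on the 4-bromophenyl series of compound 3.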